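Cytotoxicity on fibroblasts: ester to piperidinyl swap

The compounds below may be only part of what the source reports. "The series", "measured", "known", "first", "only" and "open" are said of these compounds alone.

Four compounds of one series are followed in a toxicity assay on NIH3T3 cells (Mus musculus) for cytotoxicity, read by resazurin assay; a lower number here means that less compound is needed, a higher number that more compound is needed for the effect. Compound 1 `Nc1cc(-c2ccccc2)ccc1Cn1cncc1CNc1ccc(Cl)c(-c2ccccc2)c1` returns only a limit, > 1000 nM, in this assay. Compound 2 `c1ccc(Cn2cncc2CNc2cccc(-c3ccccc3)c2)cc1` likewise returns only a limit, > 750 nM. Compound 3 `CC(C)OC(=O)c1ccc(NCc2cncn2Cc2ccc(-c3ccccc3)cc2)cc1-c1ccccc1` also returns only a limit, > 10000 nM, and so no number is known for it. All three measured values are therefore limits of the assay rather than numbers: one at the limit of > 1000 nM in this assay, at which 1 of the 3 values shown sits, one at the limit of > 750 nM in this assay, at which 1 of the 3 values shown sits, and compound 3 alone at the limit of > 10000 nM in this assay, at which 1 of the 3 values shown sits, the widest limit of the three. For the measured compounds named here, no step between two measured compounds is available, so no measured effect of any single structural change is known.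

Compound 4 `c1ccc(-c2ccc(Cn3cncc3CNc3ccc(N4CCCCC4)c(-c4ccccc4)c3)cc2)cc1` is not yet measured in this assay. It differs from compound 3 by piperidin-1-yl in place of isopropoxycarbonyl on an aromatic carbon. Going by the values given here, with no measured step to lean on, the expectation rests on the three limits alone, which show no cytotoxicity reached within the tested ranges. The step from compound 3 to compound 4, an at least 1.2-fold lower number from compound 3 to compound 4 (0.09 log units; that floor lies within the scatter), is expected to be none beyond the scatter, with a limit again the most likely outcome. Compound 4 is estimated at 8000 nM, in the range 2000 nM to 30000 nM.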

Compound 4, half-maximal effective concentration: > 1000 nM
Compound 4: only a limit was reported; the forecaster's own chance of this, stated with the estimate: 70%; the middle value does not contradict the limit.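

Compound 3 and compound 4 both return only limits in this assay, and the step between them, piperidin-1-yl in place of isopropoxycarbonyl, cannot be read. The compounds shown leave open the concentration at which any of the four reaches the half-maximal effect in this assay, and whether this swap shifts it at all.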